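A few compounds are considered here, and "the series" means these few. Any claim that something is new, unique, unknown or untested is made for them only; others in the source may bear on it.

Three compounds share one core and differ only in the aromatic group on an amide-type nitrogen. In a functional assay on NCI-H1299 cells (Homo sapiens) for inhibition, read by CCK-8 assay, with a stated time of 72 h, tested at 10 uM (a higher number here means more inhibition of growth at the concentration tested, a lower number less inhibition of growth), compound 1 `CN(C)C(=O)c1cc2cnc(Nc3ccc(NC(=O)C4(C(=O)Nc5ccc(F)cc5)CC4)cc3)nc2n1C1CCCC1`, which carries 4-fluorophenyl, gives 90.8%. Compound 2 `CN(C)C(=O)c1cc2cnc(Nc3ccc(NC(=O)C4(C(=O)Nc5cccc(O)c5)CC4)cc3)nc2n1C1CCCC1`, which carries 3-hydroxyphenyl, gives 78.5%. Compound 3 `CN(C)C(=O)c1cc2cnc(Nc3ccc(NC(=O)C4(C(=O)Nc5ccc(Cl)c(C(F)(F)F)c5)CC4)cc3)nc2n1C1CCCC1`, which carries 4-chloro-3-(trifluoromethyl)phenyl, gives 90.4%. This places compound 3 level with compound 1, as the step of a number 0.4 percentage points lower from compound 1 to compound 3 (within the scatter) shows, and clear of compound 2, as the step of a number 11.9 percentage points higher from compound 2 to compound 3 (beyond the scatter) shows.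

Going by the values given here, compound 4 `CN(C)C(=O)c1cc2cnc(Nc3ccc(NC(=O)C4(C(=O)Nc5ccc(O)cc5)CC4)cc3)nc2n1C1CCCC1` alters only this group: 4-hydroxyphenyl in place of 4-chloro-3-(trifluoromethyl)phenyl on an amide-type nitrogen. In words, 4-hydroxyphenyl replaces 4-chloro-3-(trifluoromethyl)phenyl.

Among the compounds with values here, two measured steps bear on this change. Within the data shown here, the closer guide is the step of a number 11.9 percentage points higher from compound 2 to compound 3 (beyond the scatter), read backwards, as compound 2 is the only measured compound with a hydroxyphenyl group. The step of a number 12.3 percentage points lower from compound 1 to compound 2 (beyond the scatter) is of similar size and also ends at that compound. Still, compound 2 is a single example, and its hydroxyl group is named at a different ring position, so the guide is limited. A modest fall in this assay therefore seems likely, and the estimated step is a number 11.4 percentage points lower from compound 3 to compound 4 (beyond the scatter). For compound 4, the estimated value is 79%, with an expected range from 65% to 91%.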

Compound 4, percent growth inhibition at one concentration: 89.7%
For compound 4 the middle estimate is 10.7 percentage points below the measured one, and the stated range covers the measured number.
By their numbers in this assay, from the lowest: compound 2; then compounds 4, 3 and 1 (each within the scatter of the next).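

In this assay, the new result separates the two hydroxyphenyl groups: there is a number 11.2 percentage points higher from compound 2 to compound 4 (beyond the scatter). Compound 4 also carries a hydroxyl group, yet it does not share the lower number of compound 2. Among these compounds, that lower number goes with the 3-hydroxyphenyl arrangement. Two further steps, a number 0.7 percentage points lower from compound 3 to compound 4 (within the scatter) and a number 1.1 percentage points lower from compound 1 to compound 4 (within the scatter), show that 4-hydroxyphenyl stands level with both 4-chloro-3-(trifluoromethyl)phenyl and 4-fluorophenyl, so this position accepts groups as different as these, with compound 2 the one exception among the four compounds. No measurement available here explains why the two hydroxyphenyl compounds part ways.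

Going by these compounds, with only one tested concentration, it remains open whether compound 1, compound 3 and compound 4 would stay level at lower concentrations, where differences among them might appear. On these data alone, it is also open whether the level result extends to 4-methoxyphenyl, 4-aminophenyl or 4-carboxyphenyl, or to a saturated ring such as cyclohexyl on the same amide-type nitrogen.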